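A methyl on the ring amine of compound 1

The source may hold more compounds than are shown below. What is called first, only, known or untested is meant among the compounds shown, and "the series" means these compounds.

Measured in an ADME assay on J774.A1 cells (Mus musculus) for cytotoxicity; a higher number here means that more compound is tolerated, a lower number that less compound is tolerated:
- compound 1 `COc1ccc(-c2nc(N3CCNCC3)nc3ccccc23)c(OC)c1`: 3.98 ug/mL
- compound 2 `c1ccc(N2CCN(c3nc(-n4ccc5ccccc54)c4ccccc4n3)CC2)cc1`: 5.67 ug/mL
- compound 3 `Cn1cc(-c2nc(N3CCNCC3)nc3ccccc23)c2ccccc21`: 16 ug/mL

Compound 1 has the lowest number of the three, though its gap to compound 2 lies within the scatter. Only compound 3 stands clearly higher, beyond the scatter. Compound 4 `COc1ccc(-c2nc(N3CCN(C)CC3)nc3ccccc23)c(OC)c1` differs from compound 1 by methyl in place of hydrogen on an amine nitrogen in a ring. For the measured compounds named here, no measured pair shows this change, so the expectation starts from compound 1 at 3.98 ug/mL and foresees no shift beyond the scatter in this assay. The estimated step of a 1.3-fold higher number from compound 1 to compound 4 (0.10 log units; within the scatter) is therefore small. Compound 4 is expected at 5 ug/mL, within an estimated range of 2.5 ug/mL to 11 ug/mL.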

Compound 4, half-maximal cytotoxic concentration: 18 ug/mL
Compound 4: the middle estimate sits 3.6-fold (0.56 log units) below what was measured, and the stated range ends below it.
By their numbers in this assay, from the lowest: compounds 1 and 2 (each within the scatter of the next); then compounds 3 and 4 (each within the scatter of the next).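

In this assay the change from piperazin-1-yl to 4-methylpiperazin-1-yl gives a 4.5-fold higher number from compound 1 to compound 4 (0.66 log units; beyond the scatter) and so lies beyond the scatter. For the compounds shown here, this is the first step that can be read, and it shows that a single methyl on this amine nitrogen in a ring is enough to shift the number. Nothing at hand accounts for the shift. The compounds shown leave open whether a longer chain such as ethyl, or an acetyl, on the same nitrogen would move the number as far. They also leave open whether methyl would give a similar step on compound 3.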